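The source may hold more compounds than are shown below. What is called first, only, known or untested is meant among the compounds shown, and "the series" means these compounds.

In a physicochemical assay for acid dissociation, compound 1 (`COc1cccc(CNCCCNc2ccnc3cc(C4CCCCC4)ccc23)c1O`) gives 9.47 and compound 2 (`COc1cccc(CNCCCNc2ccnc3cc(Oc4cccc(N(C)C)c4)ccc23)c1O`) gives 9.28 as its number. Compound 2 therefore stands within the usual scatter of compound 1, and the two cannot be ranked. Compound 3 (`COc1cccc(CNCCCNc2ccnc3cc(CC(C)C)ccc23)c1O`) has not yet been measured. It departs from compound 2 by a single exchange, isobutyl in place of 3-(dimethylamino)phenoxy on an aromatic carbon. For the measured compounds named here, one measured step bears on this change. Going by the values given here, the step of a number 0.19 log units lower from compound 1 to compound 2 (within the scatter) is the only exchange seen on that same aromatic carbon, and there cyclohexyl gave way to the group that compound 3 now lacks. Among the compounds with values here, no compound carrying isobutyl has a measured number, so this single step is a thin guide. On this evidence, no shift beyond the scatter is expected in this assay for the new exchange. The expected move is slightly upward, with an estimated a number 0.12 log units higher from compound 2 to compound 3 (within the scatter) as its size. For compound 3 the estimate is 9.4 with an expected range from 9.05 to 9.75 in this measurement.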

Compound 3, acid dissociation constant: 9.47
Compound 3: middle estimate off by 0.07 log units, on the low side; the range from low to high includes it.
By their numbers in this assay, from the lowest: compounds 2, 1 and 3 (each within the scatter of the next).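

In this assay, the exchange of 3-(dimethylamino)phenoxy for isobutyl gives a number 0.19 log units higher from compound 2 to compound 3 (within the scatter), and the exchange of cyclohexyl for isobutyl gives no change at the digits printed from compound 1 to compound 3 (within the scatter). The aromatic carbon has now carried three different groups without any step leaving the scatter, and this holds across the two exchanges that bring in isobutyl, even though the group leaving compound 2 has 10 heavy atoms, a ring and 2 hydrogen-bond acceptors, while isobutyl has 4 heavy atoms, no ring and no hydrogen-bond acceptors. Nothing else presented here helps to explain this result.

From the compounds shown here alone, it remains open whether a group of another kind on this aromatic carbon, such as a primary amine, a carboxylic acid or a longer chain, would also leave the number within the scatter of these three compounds. Since all three share the rest of the structure, they also give no reading of how an exchange elsewhere in the shared core would register in this assay.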